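The source may report more compounds than this note shows. Statements on the series, on what has been measured and on what is new or still open speak of the compounds shown alone.

Measured compounds:
compound 1 `CN(C)CCn1cnnc1-c1cc(Oc2ccc(NC(=O)N/N=C/c3c[nH]c4ccccc34)cc2F)ccn1`: 1300 nM
compound 2 `Cc1cc(/C=N/NC(=O)Nc2ccc(Oc3ccnc(-c4nncn4CCN(C)C)c3)c(F)c2)cc(C)c1O`: 1220 nM

In a functional assay on HT-29 cells (Homo sapiens) for cytotoxicity, read by MTT assay, with a stated time of 72 h (a higher number here means a weaker inhibitor, a lower number a stronger inhibitor), compound 1 gives 1300 nM and compound 2 gives 1220 nM. Among the measured compounds shown here, on paper compound 2 carries the smaller of the two numbers, but the only measured step, a 1.1-fold lower number from compound 1 to compound 2 (0.03 log units; within the scatter), lies within the scatter, so the two compounds stand level. Compound 3 `COc1ccc(/C=N/NC(=O)Nc2ccc(Oc3ccnc(-c4nncn4CCN(C)C)c3)c(F)c2)cc1O` has not yet been measured in this assay. It differs from compound 2 in one place: 3-hydroxy-4-methoxyphenyl in place of 4-hydroxy-3,5-dimethylphenyl on a carbon with a double bond to nitrogen. For the measured compounds named here, the single step seen so far concerned this same carbon, and there an exchange of the entire attached group moved the number hardly at all. Going by the values given here, no measured step reports on the 3-hydroxy-4-methoxyphenyl group itself. Compound 3 is therefore expected to land close to compound 2. The step expected is a 1.1-fold higher number from compound 2 to compound 3 (0.03 log units; within the scatter), staying within the scatter. The estimate for compound 3 is 1300 nM, ranging from 600 nM to 3000 nM.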

Compound 3, half-maximal inhibitory concentration: 960 nM
Compound 3: the middle estimate sits 1.4-fold (0.13 log units) above what was measured; measured number inside the range.
By their numbers in this assay, from the lowest: compounds 3, 2 and 1 (each within the scatter of the next).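

In this assay, replacing 4-hydroxy-3,5-dimethylphenyl with 3-hydroxy-4-methoxyphenyl on the carbon with a double bond to nitrogen gives a 1.3-fold lower number from compound 2 to compound 3 (0.10 log units; within the scatter) and shows that this position can take a third group without a clear shift in the number. The entering group carries 2 hydrogen-bond acceptors where the leaving group carries 1, yet the step stays within the scatter, and replacing 1H-indol-3-yl with the same group gives a 1.4-fold lower number from compound 1 to compound 3 (0.13 log units; within the scatter) as well. Nothing available explains why these numbers stay so close.

The compounds shown leave open whether this position tolerates anything other than a group built on an aromatic ring. A carboxylic acid, an amine or a longer alkyl chain on this carbon could show whether the number can move at all.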